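The compounds below may be only part of what the source reports. "The series", "measured", "known", "first", "only" and "open" are said of these compounds alone.

Compound 1 `FC(F)(F)c1ccc(CSc2nc(N3CCCCC3)c3ccccc3n2)cc1` was tested in a functional assay on PC-3 cells (Homo sapiens) for cytotoxicity, read by MTT assay, with a stated time of 72 h (a lower number here means a stronger inhibitor, a higher number a weaker inhibitor), where compound 1 gives 25500 nM. Of the two numbers recorded so far, that of compound 1 is the lowest; its nearest neighbour is compound 2 `Cc1ccccc1Nc1nc(SCc2ccc(C(F)(F)F)cc2)nc2ccccc12`, which in this assay gives 36900 nM, and the step of a 1.4-fold higher number from compound 1 to compound 2 (0.16 log units; within the scatter) lies within the scatter, so the two compounds cannot be told apart on this read-out. The next compound, compound 3 `COc1ccc(Nc2nc(SCc3ccc(C(F)(F)F)cc3)nc3ccccc23)cc1OC`, has not yet been measured in this assay. It differs from compound 1 in one place: (3,4-dimethoxyphenyl)amino in place of piperidin-1-yl on an aromatic carbon. Among the compounds with values here, the one measured step that bears on this change is the replacement of the same piperidin-1-yl by (2-methylphenyl)amino, which gave a 1.4-fold higher number from compound 1 to compound 2 (0.16 log units; within the scatter). Since that step stayed within the scatter, and no other comparison speaks to the present change, a small step is expected for a 1.4-fold higher number from compound 1 to compound 3 (0.14 log units; within the scatter), with a slight lean toward a higher number that should not exceed the scatter. Compound 3 is therefore estimated to give 35000 nM, within a range from 12000 nM to 100000 nM.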

Compound 3, half-maximal inhibitory concentration: 14100 nM
Beside the measured number, compound 3's estimate is 2.5-fold (0.39 log units) above it; low and high end bracket the measured number.
By their numbers in this assay, from the lowest: compounds 3, 1 and 2 (each within the scatter of the next, the first and the last beyond it).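

In this assay the exchange of piperidin-1-yl for (3,4-dimethoxyphenyl)amino gives a 1.8-fold lower number from compound 1 to compound 3 (0.26 log units; within the scatter) and so, like the earlier exchange for (2-methylphenyl)amino, leaves the read-out within the scatter of compound 1 at this place on the shared core. With the amino nitrogen kept, the change from 2-methylphenyl to 3,4-dimethoxyphenyl gives a 2.6-fold lower number from compound 2 to compound 3 (0.42 log units; beyond the scatter) and is the first step among these compounds to pass the scatter, though only modestly, so the ring carried on that nitrogen does register on this read-out. No measurement at hand bears on the cause of this difference.

As far as these compounds go, the step from compound 2 to compound 3 alters the methyl group and both methoxy groups at once, so it remains open which of them carries the difference, and a plain phenyl ring or a single methoxy group on that nitrogen would separate these. Also open, from the compounds shown here alone, is whether a morpholin-4-yl group or a longer chain at this place would move the number further than any of these three compounds do.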